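Changing the Carbonyl Substituent of Compound 2

The compounds below may be only part of what the source reports. "The series", "measured", "known", "first", "only" and "open" are said of these compounds alone.

In an ADME assay on L02 cells (Homo sapiens) for antiproliferative activity, read by MTT assay, with a stated time of 48 h (a higher number here means a weaker inhibitor, a lower number a stronger inhibitor), compound 1 `CCn1c(C(=O)NCCN(C)C)ccc1C(CC)(CC)c1ccc(OCCC(O)(CC)CC)c(C)c1` gives 990 nM, while compound 2 `CCn1c(C(=O)N(CCC#N)CCC#N)ccc1C(CC)(CC)c1ccc(OCCC(O)(CC)CC)c(C)c1` gives 37800 nM, the higher of the two numbers and so the weaker inhibition. Compound 3 `C=CCN(C)C(=O)c1ccc(C(CC)(CC)c2ccc(OCCC(O)(CC)CC)c(C)c2)n1CC` is not yet measured. It differs from compound 2 as follows: a group of 5 heavy atoms (4 carbon, 1 nitrogen; no ring) in place of a group of 9 heavy atoms (6 carbon, 3 nitrogen; no ring), on a carbonyl carbon. Going by the values given here, the one measured step, a 38-fold higher number from compound 1 to compound 2 (1.58 log units; beyond the scatter), also changed the group on a carbonyl carbon, and it was large. Compound 3 carries neither earlier group, so only a partial return is expected in this assay, an estimated 2.7-fold lower number from compound 2 to compound 3 (0.43 log units; beyond the scatter). Compound 3 is estimated at 14000 nM, with an expected range of 3000 nM to 45000 nM.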

Compound 3, half-maximal inhibitory concentration: 1190 nM
Compound 3: the middle estimate sits 12-fold (1.07 log units) above what was measured; the measured number lies below the stated range.
By their numbers in this assay, from the lowest: compounds 1 and 3 (each within the scatter of the next); then compound 2.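

In this assay, going by these compounds alone, replacing the group with two nitriles by allyl(methyl)amino on the carbonyl carbon gives a 32-fold lower number from compound 2 to compound 3 (1.50 log units; beyond the scatter), so the (2-(dimethylamino)ethyl)amino group of compound 1 is not the only group that gives a low number here. Two different groups give matching results, with a 1.2-fold higher number from compound 1 to compound 3 (0.08 log units; within the scatter), and among these three compounds only compound 2 stands apart. Nothing available explains this difference. Still open, going by these compounds, is whether a single nitrile would be enough to raise the number, and whether a morpholine ring or a carboxylic acid at this carbonyl carbon would keep it low.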